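Swapping Chloro for Amino on Two Fused Purine-like Cores

This account rests on a few compounds, and the source may have more. Where it says the series, first, only, none or still open, it means among the compounds named here.

Measured compounds:
- compound 1, `Fc1ccc(Cn2cnc3c(Cl)ncnc32)cc1`: 0%
- compound 2, `Fc1ccc(Cn2cnc3ncnc(Cl)c32)cc1`: 7%
- compound 3, `Nc1ncnc2c1ncn2Cc1ccc(F)cc1`: 0%

All three were tested in an assay on isolated protein for inhibition of Rho-associated protein kinase 1 (Homo sapiens), tested at 30 uM; a higher number here means more inhibition at the concentration tested (going by the name of the read-out), a lower number less inhibition. Compound 1 gives 0%, compound 2 gives 7% and compound 3 gives 0%; these numbers lie within the scatter of one another, so none of the three stands apart. Compound 3 is made from compound 1 by the change (amino in place of chloro on an aromatic carbon), and this step, no change at the digits printed from compound 1 to compound 3 (within the scatter), left the inhibition where it was. Compound 2 has the same atoms as compound 1 joined differently; how the two cores differ is not broken down here.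

Compound 4, `Nc1ncnc2ncn(Cc3ccc(F)cc3)c12`, has not yet been measured. It is made from compound 2 by the change (amino in place of chloro on an aromatic carbon), the same change as from compound 1 to compound 3, with the place described in the same words. Because the earlier step of no change at the digits printed from compound 1 to compound 3 (within the scatter) produced no change, the step of no change at the digits printed from compound 2 to compound 4 (within the scatter) is expected to be of about the same size, that is, none. For compound 4 the estimated inhibition in this assay is 7%, with a likely range from -5% to 20%.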

Compound 4, a percentage reported as inhibition, at one concentration (the size of the read-out at that concentration, not a potency): 6%
Estimate against measurement, compound 4: 1 percentage points above; low and high end bracket the measured number.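

Putting amino in place of chloro on the core of compound 2 gave a number 1 percentage points lower from compound 2 to compound 4 (within the scatter). As far as these numbers can tell, the change behaves alike on both cores: the same change on two cores in this assay, no change at the digits printed (within the scatter) from compound 1 to compound 3 and a number 1 percentage points lower (within the scatter) from compound 2 to compound 4, 1 percentage points apart, within the scatter of two such steps

This agreement is a thin result, however, since both steps are too small to read and all four compounds give readings close to no inhibition in this assay, so it does not show that the change would carry over to a compound that clearly inhibits the kinase, where a real effect could appear or differ from core to core.

The compounds shown leave open whether any other group on that aromatic carbon, such as a methoxy group, a dimethylamino group or a longer amine chain, would produce a step that stands out from the scatter. They also leave open whether replacing the fluorine on the benzyl group with, say, a carboxylic acid would alter inhibition on either core.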